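Methyl to fluoro on an aromatic carbon: compound 3 outlook

The source may report more compounds than this note shows. Statements on the series, on what has been measured and on what is new or still open speak of the compounds shown alone.

Measured so far:
compound 1 `COc1ccccc1-c1csc2cnc(Nc3ccc(C(=O)NC4CCNCC4)cc3C)nc12` — 250 nM
compound 2 `CNC(=O)c1ccc(Nc2ncc3scc(-c4ccccc4OC)c3n2)cc1` — 710 nM

In a functional assay on U-87MG ATCC cells for inhibition, with U-87 MG (Homo sapiens) as the target, read by MTT assay, with a stated time of 72 h (a higher number here means a weaker inhibitor, a lower number a stronger inhibitor), compound 1 gives the lowest of the two numbers; compound 2, the nearest, sits at a higher value that lies beyond the scatter. Compound 3 `COc1ccccc1-c1csc2cnc(Nc3ccc(C(=O)NC4CCNCC4)cc3F)nc12` has not been run yet. It differs from compound 1 by fluoro in place of methyl on an aromatic carbon. Among the measured compounds shown here, no measured pair shows this kind of change, so no step size is known; the expectation is a small shift, if any, within the scatter, and compound 3 is estimated at 300 nM (range 120 nM to 800 nM), an expected step of a 1.2-fold higher number from compound 1 to compound 3 (0.08 log units; within the scatter).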

Compound 3, half-maximal inhibitory concentration: 2370 nM
Compound 3: middle estimate off by 7.9-fold (0.90 log units), on the low side, outside the stated range (above it).
By their numbers in this assay, from the lowest: compound 1; then compound 2; then compound 3.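

In this assay fluoro in place of methyl on this aromatic carbon, ortho to a large group and meta to the (piperidin-4-yl)carbamoyl group, gives a 9.5-fold higher number from compound 1 to compound 3 (0.98 log units; beyond the scatter) and shows that this position responds strongly to a single-atom exchange. The step appears with no change in heavy-atom, donor or acceptor counts, or in net charge. No measurement at hand bears on the reason for it.

As far as these compounds go, whether methyl helps or fluoro harms stays open. Chloro, methoxy or plain hydrogen on this carbon would separate the two readings.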